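The source may report more compounds than this note shows. Statements on the series, on what has been measured and on what is new or still open speak of the compounds shown alone.

In a functional assay on HCT-116 cells (Homo sapiens) for antiproliferative activity, read by MTT assay, with a stated time of 48 h (a lower number here means a stronger inhibitor, a higher number a weaker inhibitor), compound 3 `COc1cc(-c2nnc3c(OC)cc(-c4ccc5c(ccn5C)c4)cn23)cc(OC)c1OC` has the lowest of the three numbers, at 33 nM, while compound 2 `CCOc1cc(-c2ccc3c(ccn3C)c2)cn2c(-c3cc(OC)c(OC)c(OC)c3)nnc12` gives 228 nM. Compound 4 `COc1cc(-c2nnc3c(OC4COC4)cc(-c4ccc5c(ccn5C)c4)cn23)cc(OC)c1OC` is the next case: oxetan-3-yl in place of methyl on an oxygen on an aromatic ring. The closest measured change lies on the same oxygen: a 6.9-fold lower number from compound 2 to compound 3 (0.84 log units; beyond the scatter), so the smaller group there goes with the lower number. Compound 1 `COc1cc(-c2nnc3c(OC4COC4)cc(-c4ccc5[nH]ccc5c4)cn23)cc(OC)c1OC`, which also carries (oxetan-3-yl)oxy but differs elsewhere, gives 5370 nM. A rise somewhat larger than that measured step is therefore expected in this assay, estimated as an 11-fold higher number from compound 3 to compound 4 (1.03 log units; beyond the scatter). The estimate for compound 4 is 350 nM, with an expected range of 100 nM to 1500 nM.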

Compound 4, half-maximal inhibitory concentration: 1290 nM
For compound 4 the middle estimate is 3.7-fold (0.57 log units) below the measured one; the range from low to high includes it.
By their numbers in this assay, from the lowest: compound 3; then compound 2; then compound 4; then compound 1.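

In this assay, the number on this oxygen rises beyond the scatter from methyl through ethyl to oxetan-3-yl, with oxetan-3-yl well above methyl (a 39-fold higher number from compound 3 to compound 4 (1.59 log units; beyond the scatter)) and also above ethyl (a 5.7-fold higher number from compound 2 to compound 4 (0.75 log units; beyond the scatter)). With (oxetan-3-yl)oxy held fixed, methyl in place of hydrogen on the aromatic nitrogen lowers the number (a 4.2-fold lower number from compound 1 to compound 4 (0.62 log units; beyond the scatter)), so the high value of compound 1 does not come from the oxygen substituent alone. Nothing available explains these steps.

On these data alone, whether the rise follows the size of the group or the ring oxygen of oxetan-3-yl stays open; cyclobutyl or a 2-methoxyethyl chain on the same oxygen would separate the two. As far as these compounds go, whether the nitrogen methyl gives a similar step alongside methoxy also stays open.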